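The source may hold more compounds than are shown below. What is called first, only, known or untested is meant among the compounds shown, and "the series" means these compounds.

Going by the values given here, compound 3 `CCCCCOC(=O)N1CCN(C(=O)[C@H](CCC(=O)O)NC(=O)c2cc(N3CCC(C(=O)N4CCCC4)CC3)nc(-c3ccccc3)n2)CC1` is the compound with the lowest number so far in an in vivo ADME assay on the whole organism (strain Sprague-Dawley) for pharmacokinetics, with Rattus norvegicus as the target; a higher number here means faster removal of the compound, a lower number slower removal: compound 3 gives 2 mL/min/kg, while compound 1 `CCCCCOC(=O)N1CCN(C(=O)[C@H](CCC(=O)O)NC(=O)c2cc(N3CCC(C(=O)NCC)CC3)nc(-c3ccccc3)n2)CC1` gives 8 mL/min/kg and compound 2 `CCCCCOC(=O)N1CCN(C(=O)[C@H](CCC(=O)O)NC(=O)c2cc(N3CCC(COC)CC3)nc(-c3ccccc3)n2)CC1` gives 14 mL/min/kg in this assay. The steps leading to compound 3 both went down: a 4.0-fold lower number from compound 1 to compound 3 (0.60 log units; beyond the scatter) and a 7.0-fold lower number from compound 2 to compound 3 (0.85 log units; beyond the scatter). Compound 4 `CCCCCOC(=O)N1CCN(C(=O)[C@H](CCC(=O)O)NC(=O)c2cc(N3CCC(CNC)CC3)nc(-c3ccccc3)n2)CC1` has not yet been measured in this assay. It differs from compound 3 by (methylamino)methyl in place of (pyrrolidin-1-yl)carbonyl on a saturated ring carbon. The amide is removed, and a short chain with one hydrogen-bond donor and one acceptor takes its place. Of the measured steps, the one that bears most closely is the step from compound 2 to compound 3, where a methoxymethyl group, also a short chain without a carbonyl, gave way to the (pyrrolidin-1-yl)carbonyl group and the number fell by a 7.0-fold lower number from compound 2 to compound 3 (0.85 log units; beyond the scatter); the step from compound 1 to compound 3 points the same way with a 4.0-fold lower number from compound 1 to compound 3 (0.60 log units; beyond the scatter). Undoing the amide is therefore expected to raise the number again, beyond the scatter, roughly back toward the value of compound 2. The step in this assay from compound 3 to compound 4 is expected to be a 6.0-fold higher number from compound 3 to compound 4 (0.78 log units; beyond the scatter). Compound 4 is estimated to give 12 mL/min/kg in this assay, within a range from 5 mL/min/kg to 30 mL/min/kg.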

Compound 4, clearance: 31 mL/min/kg
Compound 4: middle estimate off by 2.6-fold (0.41 log units), on the low side, and the stated range ends below it.
By their numbers in this assay, from the lowest: compound 3; then compounds 1 and 2 (each within the scatter of the next); then compound 4.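

Going by these compounds alone, at this saturated ring carbon, this assay responds more strongly than the earlier compounds showed: a 16-fold higher number from compound 3 to compound 4 (1.19 log units; beyond the scatter) is the largest step so far, and it makes compound 4 the compound with the highest number, beyond the scatter of every other compound. The result also shows that the outcome does not depend on the carbonyl alone, as neither side of a 2.2-fold higher number from compound 2 to compound 4 (0.35 log units; beyond the scatter) has one, yet methylamino in place of methoxy on the saturated chain carbon moves the number beyond the scatter. Compound 1 and compound 2 lie within the scatter of each other, but compound 4 separates from both, with a 3.9-fold higher number from compound 1 to compound 4 (0.59 log units; beyond the scatter) as the matching step from the ethylcarbamoyl group.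

The compounds shown leave open whether the low number of compound 3 goes with the pyrrolidine ring or with its carbonyl, a question that a (pyrrolidin-1-yl)methyl group at this carbon would address. They also leave open how a dimethylaminomethyl or hydroxymethyl group would compare with the (methylamino)methyl group. Nothing measured here gives a reason for these differences.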